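A Fluorine Enters the Central Ring of Compound 2

The source may hold more compounds than are shown below. What is called first, only, known or untested is meant among the compounds shown, and "the series" means these compounds.

Compound 1 `O=C(Nc1ccc(Oc2ccnc3[nH]ccc23)cc1)c1nn(-c2ccccc2)ccc1=O`: 17800 nM in a functional assay on HepG2 cells (Homo sapiens) for cytotoxicity, read by MTT assay, with a stated time of 72 h; on this read-out higher numbers stand for weaker inhibition and lower numbers for stronger inhibition
Compound 2 `O=C(Nc1ccc(Oc2ccnc3[nH]ccc23)cc1)c1nn(-c2ccc(Cl)c(C(F)(F)F)c2)ccc1=O`: 1320 nM in this assay

Of the two numbers measured in this assay, compound 2 holds the lowest; its nearest neighbour is compound 1, separated by a 13-fold lower number from compound 1 to compound 2 (1.13 log units; beyond the scatter), a large step. Compound 3 `O=C(Nc1ccc(Oc2ccnc3[nH]ccc23)c(F)c1)c1nn(-c2ccc(Cl)c(C(F)(F)F)c2)ccc1=O` is the next compound to be tested. It differs from compound 2 by fluoro in place of hydrogen on an aromatic carbon, the fluoro sitting on an aromatic carbon of a six-membered aromatic ring of carbon only, ortho to a large group and meta to a large group. Going by the values given here, the one measured step, from compound 1 to compound 2, alters the group on the aromatic nitrogen at the far side of the shared core and says nothing about a fluoro on this ring. Among the compounds with values here, with no step to lean on, no change beyond the scatter is expected in this assay, so a 1.2-fold lower number from compound 2 to compound 3 (0.08 log units; within the scatter) is the estimated step. Compound 3 is therefore expected to give 1100 nM, within a range from 400 nM to 3500 nM.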

Compound 3, half-maximal inhibitory concentration: 11900 nM
For compound 3 the middle estimate is 11-fold (1.03 log units) below the measured one; the measured number lies above the stated range.
By their numbers in this assay, from the lowest: compound 2; then compounds 3 and 1 (each within the scatter of the next).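

With fluoro in place of hydrogen on an aromatic carbon of the six-membered aromatic ring of carbon only, ortho to a large group and meta to a large group, this assay gives a 9.0-fold higher number from compound 2 to compound 3 (0.95 log units; beyond the scatter), a rise toward weaker inhibition. This position is therefore not indifferent to change: a single added heavy atom moves the number beyond the scatter, which the earlier step of a 13-fold lower number from compound 1 to compound 2 (1.13 log units; beyond the scatter), made on the aromatic nitrogen, could not reveal. Nothing measured here explains why the number rises.

The compounds shown leave open whether a chloro, a methyl or a methoxy in the same place would also raise the number. They also leave open whether the fluoro would have a similar effect with the unsubstituted phenyl of compound 1 on the aromatic nitrogen.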